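Compound 1 to compound 3: trifluoromethyl for chloro

The source may report more compounds than this note shows. Statements on the series, on what has been measured and on what is new or still open speak of the compounds shown alone.

Among the compounds with values here, in an ADME assay (liver) for pharmacokinetics, with Liver microsome (Rattus norvegicus) as the target, read by LC-MS, using microsomes, tested at 2 uM (on this read-out lower numbers stand for slow clearance and higher numbers for fast clearance), compound 1 `O=C(N[C@@H]1CCCC[C@H]1O)c1cnc(OCC2CC2)c(-c2ccc(Cl)cc2)c1` gives 0.064 mL/min/kg and holds the higher of the two numbers measured so far. Within the data shown here, the only other measured compound is compound 2 `O=C(N[C@@H]1CCCC[C@H]1O)c1cnc(OCc2ccccc2)c(-c2ccc(Cl)cc2)c1`, which gives 0.02 mL/min/kg as its value. That comparison, phenyl in place of cyclopropyl on a saturated chain carbon bound to an oxygen on an aromatic ring, is a 3.2-fold lower number from compound 1 to compound 2 (0.51 log units; beyond the scatter) and counts as a modest step.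

Compound 3 `O=C(N[C@@H]1CCCC[C@H]1O)c1cnc(OCC2CC2)c(-c2ccc(C(F)(F)F)cc2)c1` keeps the cyclopropyl of compound 1 and changes another place, with trifluoromethyl in place of chloro on an aromatic carbon. Among the measured compounds shown here, no measured step covers this swap of 4-chlorophenyl to 4-(trifluoromethyl)phenyl. For the measured compounds named here, the single available step, a 3.2-fold lower number from compound 1 to compound 2 (0.51 log units; beyond the scatter), lies at another place and offers only a rough gauge of size in this assay. No direction can be drawn from it, so no shift beyond the scatter is expected. The expected step is a 1.1-fold lower number from compound 1 to compound 3 (0.03 log units; within the scatter) and the estimate carries wide uncertainty. Compound 3 is estimated at 0.06 mL/min/kg (expected range 0.025 mL/min/kg to 0.15 mL/min/kg).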

Compound 3, clearance: 0.009 mL/min/kg
Compound 3: middle estimate off by 6.7-fold (0.82 log units), on the high side, outside the stated range (below it).
By their numbers in this assay, from the lowest: compound 3; then compound 2; then compound 1.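

In this assay, the aromatic carbon that carries the chloro group proves to be a place where the read-out responds: trifluoromethyl in place of chloro gives a 7.1-fold lower number from compound 1 to compound 3 (0.85 log units; beyond the scatter), although the change adds no ring, no hydrogen-bond donor or acceptor and no net charge. With a 3.2-fold lower number from compound 1 to compound 2 (0.51 log units; beyond the scatter), there are now two single changes from compound 1, at separate places on the shared core, and both lead to a lower clearance number, with no compound shown going against this direction. No available evidence bears on why the change from 4-chlorophenyl to 4-(trifluoromethyl)phenyl moves the number.

The compounds shown leave open whether the phenyl change and the trifluoromethyl change would add up when combined on the shared core, since each has been read only on its own against compound 1. As far as these compounds go, it also remains open whether the effect is specific to trifluoromethyl or extends to other groups on this aromatic carbon, such as a nitrile, a methoxy group or a primary amine.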